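The compounds below may be only part of what the source reports. "The series", "measured", "known", "first", "only" and "open" are said of these compounds alone.

Three compounds that share one core and differ only in the group on the carbonyl carbon have been measured in a functional assay on WI-38 VA13 cells (Homo sapiens) for cytotoxicity; a higher number here means that more compound is needed for the effect, a lower number that less compound is needed. Compound 1 `Cn1ncc([N+](=O)[O-])c1C(=O)Nc1ccc2nc(NC(=O)C3CCCCC3)sc2c1` gives 0.026 ug/mL, the lowest of the three numbers. Compound 2 `Cc1ccccc1C(=O)Nc1ccc2nc(NC(=O)C3CCCCC3)sc2c1` gives 0.085 ug/mL, and compound 3 `Cc1ccc(C(=O)Nc2ccc3nc(NC(=O)C4CCCCC4)sc3c2)cc1` gives 5.1 ug/mL. The step of a 3.3-fold higher number from compound 1 to compound 2 (0.51 log units; beyond the scatter) is modest, while a 200-fold higher number from compound 1 to compound 3 (2.29 log units; beyond the scatter) and a 60-fold higher number from compound 2 to compound 3 (1.78 log units; beyond the scatter) are large, so the group on the carbonyl carbon clearly matters in this assay.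

Compound 4 `Cn1nccc1C(=O)Nc1ccc2nc(NC(=O)C3CCCCC3)sc2c1` has not yet been measured. It differs from compound 1 in one place: hydrogen in place of nitro on an aromatic carbon. Among the compounds with values here, none of the measured steps makes this change; each swaps the whole ring on the carbonyl carbon, and no measured pair differs by a nitro alone. Within the data shown here, the measured steps show only that changes at this part of the molecule can move the number a great deal, and both of them raised it. Compound 4 is therefore expected to give a somewhat higher number than compound 1, an estimated step of a 5.8-fold higher number from compound 1 to compound 4 (0.76 log units; beyond the scatter). The estimate for compound 4 is 0.15 ug/mL, with a range from 0.03 ug/mL to 1 ug/mL.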

Compound 4, half-maximal effective concentration: 0.58 ug/mL
Compound 4: the middle estimate sits 3.9-fold (0.59 log units) below what was measured, within the range that was stated.
By their numbers in this assay, from the lowest: compound 1; then compound 2; then compound 4; then compound 3.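

In this assay the nitro group alone makes a large difference: with hydrogen in its place there is a 22-fold higher number from compound 1 to compound 4 (1.35 log units; beyond the scatter), a change in one group that the earlier swaps of the whole ring could not separate out. Without the nitro, the ring falls behind the 2-methylphenyl group, with a 6.8-fold higher number from compound 2 to compound 4 (0.83 log units; beyond the scatter), although it still compares well with the 4-methylphenyl group, with an 8.8-fold lower number from compound 3 to compound 4 (0.94 log units; beyond the scatter), so the lead of compound 1 over compound 2 depends on the nitro and not on the 1-methyl-1H-pyrazol-5-yl ring alone. Nothing measured here explains why the nitro has this effect.

On these data alone, it remains open whether only a nitro gives so low a number at this place or whether another group would do the same. An amine, a nitrile or a chlorine atom on the same aromatic carbon would test this.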